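From isobutyl to 2-phenoxyethyl on a shared core

A few compounds are considered here, and "the series" means these few. Any claim that something is new, unique, unknown or untested is made for them only; others in the source may bear on it.

Of the compounds shown here, three with one shared core have been measured in an ADME assay (liver) for pharmacokinetics, with Liver microsome (Homo sapiens) as the target, using microsomes (on this read-out higher numbers stand for a longer-lived compound and lower numbers for a shorter-lived compound), and they differ only in the group on an oxygen next to a carbonyl group. Compound 1 `CCOc1cc(NC(=O)C2(NC(=O)c3ccc4c(C5CCCC5)c(-c5ncc(Cl)cn5)n(C)c4c3)CCC2)ccc1/C=C/C(=O)OC(=O)C[C@H](O)C(=O)O` gives 5.57 h. Compound 2 `CCOc1cc(NC(=O)C2(NC(=O)c3ccc4c(C5CCCC5)c(-c5ncc(Cl)cn5)n(C)c4c3)CCC2)ccc1/C=C/C(=O)OCOP(=O)(O)OC(C)(C)C` gives 1.48 h. Compound 3 `CCOc1cc(NC(=O)C2(NC(=O)c3ccc4c(C5CCCC5)c(-c5ncc(Cl)cn5)n(C)c4c3)CCC2)ccc1/C=C/C(=O)OCC(C)C` gives > 5 h, which is a limit of the assay and not a number.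

Compound 4 `CCOc1cc(NC(=O)C2(NC(=O)c3ccc4c(C5CCCC5)c(-c5ncc(Cl)cn5)n(C)c4c3)CCC2)ccc1/C=C/C(=O)OCCOc1ccccc1` keeps the core and changes one group relative to compound 3: phenoxymethyl in place of isopropyl on a saturated chain carbon bound to an oxygen next to a carbonyl group. Put simply, 2-phenoxyethyl takes the place of isobutyl.

Going by the values given here, two measured steps bear on this change, since both alter the same group. The first is a 3.8-fold lower number from compound 1 to compound 2 (0.58 log units; beyond the scatter), and the second is an at least 3.3-fold higher number from compound 2 to compound 3 (0.52 log units; beyond the scatter). Both lie beyond the scatter, so this group can shift the half-life. Neither compound carries a 2-phenoxyethyl group, however, so the direction is only a cautious guess. With compound 3 at a limit, a modest fall seems likelier than a rise. Compound 2 at 1.48 h marks the lowest number seen so far. The step expected here is an at least 1.4-fold lower number from compound 3 to compound 4 (0.15 log units; that floor lies within the scatter). Compound 4 is estimated at 3.5 h, with an expected range of 1.5 h to 8 h.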

Compound 4, half-life: > 5 h
Compound 4: a limit, no number (the forecaster's own chance of this, stated with the estimate: 30%); at least 1.4-fold (0.15 log units) between middle value and limit.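

Compound 4 gives > 5 h in this assay, which is a limit of the assay and not a number. Going by these compounds alone, the earlier compounds carried no ring in this place, so this result is the first to show that 2-phenoxyethyl, with its six-membered aromatic ring of carbon only, can stand on this oxygen next to a carbonyl group and still reach the same limit as isobutyl: the limit of > 5 h in this assay, at which 2 of the 4 values shown sit. The one step that can be read is an at least 3.3-fold higher number from compound 2 to compound 4 (0.52 log units; beyond the scatter), which leaves compound 2 the shortest-lived of the four, while the steps to compound 4 from compound 1 and from compound 3 cannot be read.

Going by these compounds, with compound 3 and compound 4 both at the limit, their order stays open, as does how far either one lies past it. Also open, on these data alone, is what an amine, a carboxylic acid or a longer chain in this place would do to the half-life, and whether any of them would give a number that could be read against compound 2.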